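Amide substituent change on the shared core

The source may hold more compounds than are shown below. What is called first, only, known or untested is meant among the compounds shown, and "the series" means these compounds.

Measured compounds:
compound 1, `CCN1CCc2nc(C#Cc3ccccc3)sc2C1`, 1200 nM
compound 2, `O=C(C1CC1)N1CCc2nc(C#Cc3ccccc3)sc2C1`, 290 nM

Among the measured compounds shown here, in an assay on HEK293 cells for negative allosteric modulation of metabotropic glutamate receptor 5 (Homo sapiens), read by FLIPR, with a stated time of 1 h (a lower number here means a stronger inhibitor, a higher number a weaker inhibitor), compound 2 gives the lowest of the two numbers obtained so far; the nearest is compound 1, and the one measured step, a 4.1-fold lower number from compound 1 to compound 2 (0.62 log units; beyond the scatter), separates them. That step replaced an ethyl on the ring amine nitrogen with a cyclopropylcarbonyl.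

Compound 3, `COC1CC(C(=O)N2CCc3nc(C#Cc4ccccc4)sc3C2)C1`, keeps the carbonyl on that nitrogen and changes only the group attached to the carbonyl carbon: 3-methoxycyclobutyl in place of cyclopropyl on a carbonyl carbon.

For the measured compounds named here, no measured step bears directly on this change. The step from compound 1 to compound 2 altered the same position, but it exchanged an alkyl for an acyl group, whereas here one acyl group is exchanged for a larger one. Without a measured precedent for the change at the carbonyl carbon, no shift beyond the scatter is expected in this assay.

The estimate for compound 3 is therefore close to compound 2: 300 nM, within 100 nM to 900 nM, which is expected to mean a 1.0-fold higher number from compound 2 to compound 3 (0.01 log units; within the scatter).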

Compound 3, half-maximal inhibitory concentration: > 10000 nM
Compound 3 gave a limit, no number; the forecaster's own chance of this, stated with the estimate: 5%; at least 33-fold (1.52 log units) between middle value and limit.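

In this assay compound 3 gives a limit of the assay and not a number: the limit of > 10000 nM in this assay, at which 1 of the 3 values shown sits. With the carbonyl kept on the ring nitrogen, putting 3-methoxycyclobutyl in place of cyclopropyl on a carbonyl carbon gives an at least 34-fold higher number from compound 2 to compound 3 (1.53 log units; beyond the scatter), so the group on the carbonyl carbon can by itself decide whether these amides read as inhibitors here, something the earlier alkyl-to-acyl step could not show. An acyl group on this nitrogen also does not guarantee a lower number than ethyl: one acyl group gives a 4.1-fold lower number from compound 1 to compound 2 (0.62 log units; beyond the scatter), whereas another gives an at least 8.3-fold higher number from compound 1 to compound 3 (0.92 log units; beyond the scatter), a change in the opposite direction.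

Compound 3 differs from compound 2 in both ring size and the added methoxy group, so the compounds shown do not tell which of these features accounts for the large step. Going by these compounds, it also remains open how a plain cyclobutyl, an isopropyl or a tert-butyl on the carbonyl carbon would read in this assay, and whether any such group could give a lower number than compound 2.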